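The source may hold more compounds than are shown below. What is called first, only, known or untested is meant among the compounds shown, and "the series" means these compounds.

Measured compounds:
compound 1, `O=c1cc(-c2ccccc2)oc2cccc(OCCCCCCCN3CCC(O)CC3)c12` — 36 nM
compound 2, `CN(C)CCCCCCCCOc1ccc2oc(-c3ccccc3)cc(=O)c2c1` — 227 nM

In an assay on isolated protein (Cavia porcellus) with Sigma non-opioid intracellular receptor 1 (Homo sapiens) as the target, read by radioligand binding (a higher number here means a weaker inhibitor, a lower number a stronger inhibitor), compound 1 gives 36 nM and compound 2 gives 227 nM. Of these two numbers, compound 2 holds the higher one, and its gap to compound 1 lies beyond the usual scatter of repeated measurements, so compound 2 is the weaker inhibitor of the pair. Compound 3, `O=c1cc(-c2ccccc2)oc2ccc(OCCCN3CCC(O)CC3)cc12`, has not yet been measured. It differs from compound 2 in one place: 4-hydroxypiperidin-1-yl in place of 5-(dimethylamino)pentyl on a saturated chain carbon, three bonds along the chain from an oxygen on an aromatic ring. Compound 3 thus carries the same 4-hydroxypiperidin-1-yl group as compound 1, now on a chain of different length. Among the measured compounds shown here, no single-change step between measured compounds is available to set the size of this move. Since compound 1 gives 36 nM with that same group, compound 3 is expected to land at a lower number than compound 2. The expected step is a 4.5-fold lower number from compound 2 to compound 3 (0.66 log units; beyond the scatter). The estimate for compound 3 is 50 nM, with a likely range from 10 nM to 300 nM.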

Compound 3, half-maximal inhibitory concentration: 130 nM
Beside the measured number, compound 3's estimate is 2.6-fold (0.41 log units) below it; the range from low to high includes it.
By their numbers in this assay, from the lowest: compound 1; then compounds 3 and 2 (each within the scatter of the next).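

In this assay, the change gives a 1.7-fold lower number from compound 2 to compound 3 (0.24 log units; within the scatter), a step within the scatter, so at this place on the chain the two groups cannot be told apart by their numbers. This single swap removes the open dimethylamino end along with its long chain and brings in the ring with its hydroxyl, so the step cannot be divided between those parts. Compound 1 differs from compound 3 in more than one place, and nothing available here gives a reason for the result.

The compounds shown leave open whether a longer chain carrying 4-hydroxypiperidin-1-yl at the attachment point of compound 3 would move the number beyond the scatter. They also leave open whether a plain piperidin-1-yl group, without the hydroxyl, would read any differently on the chain of compound 3.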